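Shortening the alkyl arm on the sulfur

A few compounds are considered here, and "the series" means these few. Any claim that something is new, unique, unknown or untested is made for them only; others in the source may bear on it.

compound 1 `CC(C)C(Sc1nc2c(cnn2C)c(=O)n1-c1ccccc1)c1ccccc1` — 300 nM
compound 2 `CCC(Sc1nc2c(cnn2C)c(=O)n1-c1ccccc1)c1ccccc1` — 179 nM

In an assay on isolated protein for inhibition of retinal dehydrogenase 2 (Homo sapiens) (a higher number here means a weaker inhibitor, a lower number a stronger inhibitor), compound 1 gives 300 nM and compound 2 gives 179 nM. Compound 2 holds the lower of the two numbers, though its gap to compound 1 lies within the scatter. Among the compounds with values here, the only measured step, a 1.7-fold lower number from compound 1 to compound 2 (0.22 log units; within the scatter), removes one carbon from the saturated chain and is the sole step bearing on the next change. Compound 3 `C[C@H](Sc1nc2c(cnn2C)c(=O)n1-c1ccccc1)c1ccccc1` carries 1-phenylethyl in place of 1-phenylpropyl on a sulfur. A chain shortening of the same kind is expected to move the number little, if at all, beyond the scatter. Compound 3 is therefore expected to give 150 nM (range 60 nM to 400 nM). This corresponds to an expected step of a 1.2-fold lower number from compound 2 to compound 3 (0.08 log units; within the scatter).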

Compound 3, half-maximal inhibitory concentration: 1480 nM
Compound 3: middle estimate off by 9.9-fold (0.99 log units), on the low side, and the stated range ends below it.
By their numbers in this assay, from the lowest: compounds 2 and 1 (each within the scatter of the next); then compound 3.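

On a sulfur whose other neighbours are aromatic carbon, the change to 1-phenylethyl gives an 8.3-fold higher number from compound 2 to compound 3 (0.92 log units; beyond the scatter) in this assay and so, unlike a 1.7-fold lower number from compound 1 to compound 2 (0.22 log units; within the scatter), marks a change at this position that lies beyond the scatter. The entering 1-phenylethyl also brings a defined stereocentre, so this step does not separate chain length from stereochemistry. No measurement at hand accounts for the step.

Going by these compounds, the mirror-image form of 1-phenylethyl remains open, as does a plain benzyl group on the sulfur. A longer chain than 1-phenylpropyl is also untested among the compounds shown.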